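The source may report more compounds than this note shows. Statements on the series, on what has been measured and on what is new or still open speak of the compounds shown alone.

In a functional assay on MCF7 cells (Homo sapiens) for antiproliferative activity, read by MTT assay, with a stated time of 48 h (a higher number here means a weaker inhibitor, a lower number a stronger inhibitor), compound 1 (`COc1ccc(/C=C/C(=O)Nc2nnc(-c3ccc(C)cc3)s2)cc1`) gives 0.35 ug/mL and compound 2 (`Cc1ccc(/C=C/C(=O)Nc2nnc(-c3ccc(C)cc3)s2)cc1`) gives 0.61 ug/mL as its value. Only these two numbers exist so far, and they lie within the scatter of each other, so compound 1 cannot be ranked apart from compound 2. Compound 3 (`COc1ccc(/C=C/C(=O)Nc2nnc(-c3ccc(Br)cc3)s2)cc1`) differs from compound 1 by bromo in place of methyl on an aromatic carbon, that is, 4-methylphenyl to 4-bromophenyl. For the measured compounds named here, the only measured step is a 1.7-fold higher number from compound 1 to compound 2 (0.24 log units; within the scatter) and it swaps methoxy for methyl, leaving the 4-methylphenyl group untouched, so it bears only loosely on this change. Going by the values given here, no measured compound varies that methyl group, so no step beyond the scatter is expected in this assay for compound 3. The estimated step is a 1.1-fold higher number from compound 1 to compound 3 (0.06 log units; within the scatter) and it stays within the scatter. For compound 3 the estimated value is 0.4 ug/mL with an expected range from 0.15 ug/mL to 1.1 ug/mL in this measurement.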

Compound 3, half-maximal inhibitory concentration: 1.13 ug/mL
Beside the measured number, compound 3's estimate is 2.8-fold (0.45 log units) below it; measured number above the stated range.
By their numbers in this assay, from the lowest: compounds 1, 2 and 3 (each within the scatter of the next, the first and the last beyond it).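

For the compounds shown here, the earlier step touched only the methoxy end of the molecule, so this is the first look at the group on the other side. In this assay, bromo in place of methyl, on an aromatic carbon para to a large group, gives a 3.2-fold higher number from compound 1 to compound 3 (0.51 log units; beyond the scatter) and makes compound 3 a modestly weaker inhibitor than compound 1, so this position does respond to change. Methyl and bromo each count one heavy atom and neither adds a hydrogen-bond donor or acceptor, and no available evidence explains the shift.

From the compounds shown here alone, it remains open whether the loss is specific to bromo or would follow other replacements of methyl here, such as an amine, a carboxylic acid or a longer chain. It is also unknown whether the same swap would have a similar effect with methyl in place of methoxy at the other end.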